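The compounds below may be only part of what the source reports. "The series", "measured", "known", "first", "only" and "open" are said of these compounds alone.

Measured so far in a toxicity assay on HeLa cells (Homo sapiens) for cytotoxicity; a higher number here means that more compound is tolerated, a lower number that less compound is tolerated:

compound 2 `COc1ccc(-c2ccc([C@@H](c3ccccc3)[C@@](O)(CCN(C)C)c3cccc4ccccc34)c(OC)n2)cc1` — > 64 ug/mL
compound 3 `COc1nc(-c2ccc(C(F)(F)F)cc2)ccc1[C@@H](c1ccccc1)[C@@](O)(CCN(C)C)c1cccc2ccccc12` — > 64 ug/mL
compound 1 `COc1nc(-c2cccc(Cl)c2)ccc1[C@@H](c1ccccc1)[C@@](O)(CCN(C)C)c1cccc2ccccc12` — "nd" (no result reported)

Compound 3 gives only a limit in this assay, > 64 ug/mL, so its place among the numbers is not fixed. Compound 2 likewise gives only a limit, > 64 ug/mL. Compound 1 has no reported result at all. Going by the values given here, with two limits and one missing entry, the single measured step, a step that the two limits leave unreadable from compound 2 to compound 3, cannot be read in either size or direction; what the two values share is described by the limit of > 64 ug/mL in this assay, at which 2 of the 3 values shown sit.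

Compound 4 `COc1nc(-c2ccccc2Cl)ccc1[C@@H](c1ccccc1)[C@@](O)(CCN(C)C)c1cccc2ccccc12` differs from compound 3 by 2-chlorophenyl in place of 4-(trifluoromethyl)phenyl on an aromatic carbon. Among the compounds with values here, no measured step gives a readable size for a change of this kind, so nothing beyond the scatter can be expected in this assay in either direction. The most likely outcome is that compound 4 again reaches the limit rather than a number. Compound 4 is therefore estimated at 80 ug/mL, with a range from 40 ug/mL to 160 ug/mL, which would mean an expected step that the limit leaves unreadable from compound 3 to compound 4.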

Compound 4, half-maximal cytotoxic concentration: > 64 ug/mL
Compound 4 gave a limit, no number (the forecaster's own chance of this, stated with the estimate: 70%); the middle value lies beyond the limit too.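

Compound 4 gives only a limit in this assay, > 64 ug/mL. No step among compound 2, compound 3 and compound 4 can be read, as all three stop at the same limit: the limit of > 64 ug/mL in this assay, at which 3 of the 4 values shown sit.

On these data alone, whether 4-methoxyphenyl, 4-(trifluoromethyl)phenyl and 2-chlorophenyl differ at all in how much compound is tolerated stays open.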